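Notes on the shared core: benzyloxy aniline variants

The source may report more compounds than this note shows. Statements on the series, on what has been measured and on what is new or still open speak of the compounds shown alone.

The series shares the core shown in compound 1 `CCOC(=O)c1c(C)oc2ncnc(Nc3ccccc3)c12`, which in a functional assay on MCF7 cells (Homo sapiens) for cytotoxicity, read by MTT assay, with a stated time of 72 h (a higher number here means a weaker inhibitor, a lower number a stronger inhibitor), gives 851000 nM. Compound 2 `Cc1cccc(Nc2ncnc3oc(C)c(C(=O)O)c23)c1`, carrying a carboxylic acid in place of the ester and a methyl on the aniline, gives 57500 nM. Compound 3 `CCOC(=O)c1c(C)oc2ncnc(Nc3ccc(OCc4cccc(Cl)c4)cc3)c12` gives 54000 nM, the lowest number of the three, though its gap to compound 2 lies within the scatter; only the gap to compound 1 is clear, and that step was a 16-fold lower number from compound 1 to compound 3 (1.20 log units; beyond the scatter), with (3-chlorobenzyl)oxy in place of hydrogen on an aromatic carbon.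

Compound 4 `CCOC(=O)c1c(C)oc2ncnc(Nc3ccc(OCc4ccccc4)cc3)c12` is the next variant. The change from compound 3 is hydrogen in place of chloro on an aromatic carbon. Within the data shown here, no measured pair isolates this chloro: the one step touching the benzyloxy arm, from compound 1 to compound 3, introduces the whole group at once, so it sets the scale but not the part owed to chlorine. The expected step in this assay is therefore small, a 1.5-fold higher number from compound 3 to compound 4 (0.17 log units; within the scatter), with no direction claimed beyond the scatter. Compound 4 is estimated at 80000 nM, in the range 30000 nM to 220000 nM.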

Compound 4, half-maximal inhibitory concentration: > 1000000 nM
Compound 4: a limit, no number; the forecaster's own chance of this, stated with the estimate: 10%; middle value at least 12-fold (1.09 log units) from the limit.
By their numbers in this assay, from the lowest: compounds 3 and 2 (each within the scatter of the next); then compound 1. At a limit, above all of these: compound 4.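

Compound 4 gives a limit of the assay and not a number: the limit of > 1000000 nM in this assay, at which 1 of the 4 values shown sits. Set against compound 3, this separates the chloro from the rest of the arm for the first time: swapping it for hydrogen gives an at least 18-fold higher number from compound 3 to compound 4 (1.26 log units; beyond the scatter). Benzyloxy without chlorine gives an at least 1.1-fold higher number from compound 1 to compound 4 (0.07 log units; that floor lies within the scatter), so it shows no lowering of the number against the bare aniline, and the clear gain of compound 3 over compound 1 holds only for the 3-chlorobenzyl arm as a whole.

Going by these compounds, whether fluoro, bromo, methyl or methoxy at this place would keep the number of compound 3 stays open, as does the effect of moving the chloro elsewhere on that ring. Also open, on these data alone, is how a carboxylic acid in place of the ester would read alongside the 3-chlorobenzyl arm, since compound 2 differs from compound 3 in more than one place.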